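Adding a chloro group to compound 3

This account rests on a few compounds, and the source may have more. Where it says the series, first, only, none or still open, it means among the compounds named here.

compound 1 `N#Cc1nc2c(-c3nc4ccccc4[nH]3)c(N)n(CCN3CCCC3)c2nc1C#N`: > 50000 nM
compound 2 `N#Cc1nc2c(-c3nc4ccccc4[nH]3)c(N)n(CCCO)c2nc1C#N`: > 50000 nM
compound 3 `CCN(CC)CCCCn1c(N)c(-c2nc3ccccc3[nH]2)c2nc(C#N)c(C#N)nc21`: 640 nM

Among the compounds with values here, in a functional assay on cells (Homo sapiens) for antiproliferative activity, read by MTT assay, with a stated time of 48 h (on this read-out higher numbers stand for weaker inhibition and lower numbers for stronger inhibition), compound 3 gives 640 nM, the only exact number so far. Compound 1 gives > 50000 nM, which is a limit of the assay. Compound 2 gives > 50000 nM, also a limit.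

Compound 4 `CCN(CC)CCCCn1c(N)c(-c2nc3cc(Cl)ccc3[nH]2)c2nc(C#N)c(C#N)nc21` keeps the chain of compound 3 and carries one new group: chloro in place of hydrogen on an aromatic carbon. The large measured steps, an at least 78-fold lower number from compound 1 to compound 3 (1.89 log units; beyond the scatter) and an at least 78-fold lower number from compound 2 to compound 3 (1.89 log units; beyond the scatter), both change the chain, so neither sets a size for this change. A small change with no firm direction is therefore expected, and the estimated step is a 1.3-fold lower number from compound 3 to compound 4 (0.11 log units; within the scatter). For compound 4 the estimated value is 500 nM, with an expected range of 150 nM to 1800 nM.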

Compound 4, half-maximal inhibitory concentration: 2840 nM
Beside the measured number, compound 4's estimate is 5.7-fold (0.75 log units) below it; measured number outside the range, above it.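

Going from 1H-benzimidazol-2-yl to 5-chloro-1H-benzimidazol-2-yl gives a 4.4-fold higher number from compound 3 to compound 4 (0.65 log units; beyond the scatter) in this assay. This is the first change shown away from the chain, and it shows that this aromatic carbon is not indifferent to substitution: one chlorine atom weakens inhibition, though only modestly beside the large chain steps. Nothing measured here accounts for this shift. Going by these compounds, whether a smaller fluoro group or a methoxy group on the same carbon would shift the number in the same direction stays open. So does whether chloro would have the same effect on a different chain.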